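Swapping the aryl group on the piperazine: compound 4

A few compounds are considered here, and "the series" means these few. Any claim that something is new, unique, unknown or untested is made for them only; others in the source may bear on it.

Measured so far:
- compound 1, `Nc1scc(CN2CCN(c3ccc(Cl)c(C(F)(F)F)c3)CC2)c1C(=O)c1ccc(Cl)cc1`: -47%
- compound 2, `Nc1scc(CN2CCN(c3ccc(OC(F)(F)F)cc3)CC2)c1C(=O)c1ccc(Cl)cc1`: -51%
- compound 3, `Nc1scc(CN2CCN(c3cc(F)cc(F)c3)CC2)c1C(=O)c1ccc(Cl)cc1`: -66%

These three share one core and differ only in the aryl group on the ring amine nitrogen. In a functional assay on CHO cells with adenosine receptor A1 (Homo sapiens) as the target, read by cAMP accumulation and immunoassay, with a stated time of 6 min, tested at 1 uM (a higher number here means a weaker effect of the compound at the concentration tested, a lower number a stronger effect), compound 3 gives the lowest number of the three. The steps of a number 19 percentage points lower from compound 1 to compound 3 (beyond the scatter) and a number 15 percentage points lower from compound 2 to compound 3 (beyond the scatter) were both beyond the scatter, while a number 4 percentage points lower from compound 1 to compound 2 (within the scatter) was not.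

Compound 4, `Nc1scc(CN2CCN(c3ccc(Cl)c(Cl)c3)CC2)c1C(=O)c1ccc(Cl)cc1`, has not been measured. The change is 3,4-dichlorophenyl in place of 3,5-difluorophenyl on an amine nitrogen in a ring. The two steps that lead into compound 3 each went lower when 3,5-difluorophenyl entered; leaving it is expected to reverse part of that, a modest step upward in this assay, estimated as a number 14 percentage points higher from compound 3 to compound 4 (beyond the scatter). Compound 4 is therefore expected to give about -52%, within -68% to -36%.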

Compound 4, a percentage reported as activity, at one concentration (the size of the read-out at that concentration, not a potency): -60%
Compound 4: the middle estimate sits 8 percentage points above what was measured, and the stated range covers the measured number.
By their numbers in this assay, from the lowest: compounds 3, 4, 2 and 1 (each within the scatter of the next, the first and the last beyond it).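

In this assay, 3,4-dichlorophenyl cannot be told apart from the two groups closest to it, as neither a number 6 percentage points higher from compound 3 to compound 4 (within the scatter) nor a number 9 percentage points lower from compound 2 to compound 4 (within the scatter) clears the usual scatter. The swap of a single group, chloro in place of trifluoromethyl on an aromatic carbon, does give a real step, a number 13 percentage points lower from compound 1 to compound 4 (beyond the scatter), so one substituent on this aryl ring can shift the read-out. Nothing measured here gives a reason for these steps.

Still open, going by these compounds, is how an unsubstituted phenyl, or an aryl ring bearing an amine or a carboxylic acid, would behave at this position. A reading at one concentration also leaves the potency of these compounds unknown.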